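Solubility in a fluorinated quinazolinone biaryl ether series

A few compounds are considered here, and "the series" means these few. Any claim that something is new, unique, unknown or untested is made for them only; others in the source may bear on it.

The series shares one core, seen in compound 1 `O=c1ncn(Cc2c(F)cc(F)cc2F)c2ccc(Oc3cccc(-c4ccc5[nH]ccc5c4)c3C(F)(F)F)cc12` and its analogue compound 2 `O=c1ncn(Cc2c(F)cc(F)cc2F)c2ccc(Oc3cccc(-c4ccc5[nH]cnc5c4)c3C(F)(F)F)cc12`. In a physicochemical assay for solubility, using the shake flask method, with a stated time of 24 h, at pH 6.8 (a lower number here means a less soluble compound, a higher number a more soluble compound), compound 1 gives < 0.1 ug/mL, which is a limit of the assay and not a number. In this assay compound 2 likewise gives < 0.1 ug/mL, again a limit. Going by the values given here, the only measured step, a step that the two limits leave unreadable from compound 1 to compound 2, therefore cannot be sized, since (the limit of < 0.1 ug/mL in this assay, at which 2 of the 2 values shown sit).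

Compound 3 `Cc1cc(-c2cccc(Oc3ccc4c(c3)c(=O)ncn4Cc3c(F)cc(F)cc3F)c2C(F)(F)F)cnc1N` is not yet measured. It differs from compound 1 as follows: 6-amino-5-methylpyridin-3-yl in place of 1H-indol-5-yl on an aromatic carbon. Among the compounds with values here, no measured step bears on this change beyond the unreadable one above, so nothing in the data fixes its size or direction; all that is known is that compound 1 sits at the limit, and any measurable value for compound 3 would lie above it. Within the data shown here, the expectation is thus only that compound 3 is estimated to rise out of the limit by a step of an at least 5.0-fold higher number from compound 1 to compound 3 (0.69 log units; beyond the scatter), with a real chance that this assay again reports only a limit. Compound 3 is estimated at 0.5 ug/mL, with a range of 0.1 ug/mL to 5 ug/mL.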

Compound 3, solubility: < 0.1 ug/mL
Compound 3: only a limit was reported; the forecaster's own chance of this, stated with the estimate: 40%; at least 5.0-fold (0.69 log units) between middle value and limit.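

In this assay no step can be read among compound 1, compound 2 and compound 3, since all three sit at the same limit of the assay: the limit of < 0.1 ug/mL in this assay, at which 3 of the 3 values shown sit.

The compounds shown leave open how soluble each of the three really is, and whether either replacement of 1H-indol-5-yl changes solubility at all.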